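Removing the chloro group from compound 1

The compounds below may be only part of what the source reports. "The series", "measured", "known", "first", "only" and "open" are said of these compounds alone.

In a functional assay (liver, strain Wistar albino) for inhibition, with Liver microsome (Rattus norvegicus) as the target, using microsomes, with a stated time of 1 h (a lower number here means a stronger inhibitor, a higher number a weaker inhibitor), compound 1 (`O=c1cc(-c2ccc(Cl)c([N+](=O)[O-])c2)oc2ccccc12`) gives 80 ug/mL. Among the measured compounds shown here, its only measured neighbour, compound 2 (`O=c1cc(-c2ccc(Cl)cc2)oc2ccccc12`), gives 60 ug/mL, so the two stand level within the usual scatter of repeated measurements. Compound 3 (`O=c1cc(-c2cccc([N+](=O)[O-])c2)oc2ccccc12`) has not yet been measured. It differs from compound 1 in one place: hydrogen in place of chloro on an aromatic carbon. Put simply, this is hydrogen in place of chloro on an aromatic carbon, while the nitro group stays.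

For the measured compounds named here, only one measured step bears on this change: a 1.3-fold lower number from compound 1 to compound 2 (0.12 log units; within the scatter). That step put hydrogen in place of nitro and kept the chloro, so it is a related change but not the same one. Going by the values given here, no measurement yet shows what removing the chloro alone does. With that single step inside the scatter, no shift beyond the scatter is expected in this assay, and no direction is clearly favoured. The estimated step is a 1.1-fold lower number from compound 1 to compound 3 (0.06 log units; within the scatter). Compound 3 is expected at about 70 ug/mL, with an estimated range from 35 ug/mL to 140 ug/mL.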

Compound 3, half-maximal inhibitory concentration: 60 ug/mL
Compound 3: the middle estimate sits 1.2-fold (0.07 log units) above what was measured; measured number inside the range.
By their numbers in this assay, from the lowest: compounds 2, 3 and 1 (each within the scatter of the next).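

Putting hydrogen in place of chloro gives a 1.3-fold lower number from compound 1 to compound 3 (0.12 log units; within the scatter) in this assay, so losing the chlorine atom from this aromatic carbon, ortho to a nitro group, produces no shift that can be told apart from repeat measurements. Among the compounds shown here, earlier, the only change on record was at the nitro group, with a 1.3-fold lower number from compound 1 to compound 2 (0.12 log units; within the scatter) also inside the scatter, and the chloro position had no result of its own. Now each of the two groups on compound 1 has been replaced by hydrogen on its own, and in both cases the numbers stand level in this assay. Nothing available explains why the numbers stay level, and no finding here links this result to any property of the chloro group.

Open still is what happens when the chloro and nitro groups are both replaced by hydrogen, a case that neither single step can settle. Hydrogen is also the only replacement shown at this position, so it remains unknown whether an amine, a carboxylic acid or a longer chain there would move the number beyond the scatter.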